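The compounds below may be only part of what the source reports. "The series", "measured", "known", "first", "only" and "open" are said of these compounds alone.

Compound 1 `O=C1C(Nc2ccc(I)cc2)=CC(=O)c2c1nc1n2[C@H]2OC[C@@H](O)[C@H]2OC1` carries an iodo group on its aromatic ring. In a functional assay on MGC-803 cells (Homo sapiens) for inhibition, read by sulforhodamine B assay (on this read-out higher numbers stand for weaker inhibition and lower numbers for stronger inhibition), compound 1 gives 2150 nM, the second highest of the three numbers. Compound 2 `O=C1C=C(NCc2ccccc2)C(=O)c2c1nc1n2[C@H]2OC[C@@H](O)[C@H]2OC1` gives 2670 nM, within the scatter of compound 1, while compound 3 `Cc1ccc(NC2=CC(=O)c3nc4n(c3C2=O)[C@H]2OC[C@@H](O)[C@H]2OC4)cc1C` gives 860 nM, a lower number beyond it. For the measured compounds named here, the one measured step, a 3.1-fold lower number from compound 2 to compound 3 (0.49 log units; beyond the scatter), exchanges the whole group on the amine nitrogen and does not touch a substituent on the ring. Compound 4 `CCOc1ccc(NC2=CC(=O)c3c(nc4n3[C@H]3OC[C@@H](O)[C@H]3OC4)C2=O)cc1` differs from compound 1 by ethoxy in place of iodo on an aromatic carbon. Going by the values given here, no measured step exchanges one ring substituent for another, so no shift beyond the scatter is expected in either direction. Compound 4 is therefore expected to give 1800 nM, between 700 nM and 4500 nM, an expected step of a 1.2-fold lower number from compound 1 to compound 4 (0.08 log units; within the scatter).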

Compound 4, half-maximal inhibitory concentration: 2090 nM
For compound 4 the middle estimate is 1.2-fold (0.06 log units) below the measured one; measured number inside the range.
By their numbers in this assay, from the lowest: compound 3; then compounds 4, 1 and 2 (each within the scatter of the next).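

In this assay, for the compounds shown here, ethoxy in place of iodo gives a 1.0-fold lower number from compound 1 to compound 4 (0.01 log units; within the scatter), the one measured step that exchanges a substituent on the ring rather than the whole group on the amine nitrogen. At this place on the ring, a single iodine and the three heavy atoms of ethoxy, which add a hydrogen-bond acceptor, are not told apart by this read-out. Nothing at hand bears on why this is so.

The compounds shown leave open whether an amine or a carboxylic acid at this place would shift the number. They also leave open whether a longer chain in place of ethoxy would do so.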